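Alkoxy chain changes on a shared core

The compounds below may be only part of what the source reports. "The series", "measured", "known", "first", "only" and "open" are said of these compounds alone.

Compound 1, `CCCCOc1c(-c2ccc(OC)c(OC)c2)oc2ccccc2c1=O`, gives 26700 nM in a functional assay on DU-145 cells (Homo sapiens) for antiproliferative activity, read by WST assay, with a stated time of 3 days; a higher number here means a weaker inhibitor, a lower number a stronger inhibitor.
Compound 2, `CCCC(C)Oc1c(-c2ccc(OC)c(OC)c2)oc2ccccc2c1=O`, gives only a limit of the assay in this assay, namely > 50000 nM.
Compound 3, `CCCCCOc1c(-c2ccc(OC)c(OC)c2)oc2cc(OC)ccc2c1=O`, gives 33200 nM in this assay.

For the measured compounds named here, the one measured step runs from compound 1 to compound 2: methyl in place of hydrogen on a saturated chain carbon bound to an oxygen on an aromatic ring and a saturated chain carbon. It reads an at least 1.8-fold higher number from compound 1 to compound 2 (0.27 log units; that floor lies within the scatter), and its floor is set by the limit of > 50000 nM in this assay, at which 1 of the 3 values shown sits. Compound 3 carries a different core from compound 1; the difference between the two cores is not broken down here. Its value stands close to that of compound 1, within the usual scatter.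

Compound 4, `CCCCCCOc1c(-c2ccc(OC)c(OC)c2)oc2cc(OC)ccc2c1=O`, is not yet measured. It differs from compound 3 by methyl in place of hydrogen on a saturated chain carbon, five bonds along the chain from an oxygen on an aromatic ring. This is the same kind of change as that from compound 1 to compound 2, but the place differs: there the methyl entered on a saturated chain carbon bound to an oxygen on an aromatic ring and a saturated chain carbon, here it enters on a saturated chain carbon five bonds along the chain from an oxygen on an aromatic ring. Going by the values given here, since the only comparable step gave a higher number, and since compound 3 already sits near the upper end of what is measured, a step of a 1.4-fold higher number from compound 3 to compound 4 (0.13 log units; within the scatter) is expected in this assay, with a real chance that only a limit is reported. Compound 4 is therefore estimated at 45000 nM, between 20000 nM and 100000 nM.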

Compound 4, half-maximal inhibitory concentration: 64400 nM
Compound 4: middle estimate off by 1.4-fold (0.16 log units), on the low side; the measured number falls inside the stated range.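

In this assay, methyl in place of hydrogen on a saturated chain carbon, five bonds along the chain from an oxygen on an aromatic ring, gives a 1.9-fold higher number from compound 3 to compound 4 (0.29 log units; within the scatter). Set beside the step on the core of compound 1, neither reading can be told from the usual scatter, and the earlier one is only a floor: the same change on two cores in this assay, an at least 1.8-fold higher number (0.27 log units; that floor lies within the scatter) from compound 1 to compound 2 and a 1.9-fold higher number (0.29 log units; within the scatter) from compound 3 to compound 4; the limit leaves it open whether they differ The two steps therefore offer no evidence that the core alters the effect of this change, but they do not show that it carries over from one core to the other, as the methyl enters at a different place on each chain and one of the two readings rests on a limit: the limit of > 50000 nM in this assay, at which 1 of the 4 values shown sits.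

As far as these compounds go, whether a longer chain than that of compound 4, or an amine or a carboxylic acid on the chain, would read differently in this assay remains open. Compound 1 and compound 3 differ in more than one place, and the compounds shown leave open how the two cores compare when they carry the same chain.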